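A few compounds are considered here, and "the series" means these few. Any claim that something is new, unique, unknown or untested is made for them only; others in the source may bear on it.

Compound 1 `ClCc1ccccc1Cn1cnc2c(Cl)nc(Cl)nc21` carries two chloro groups on its core and gives 4670 nM in a functional assay on SN12C cells (Homo sapiens) for cytotoxicity, read by sulforhodamine B assay, with a stated time of 48 h; on this read-out lower numbers stand for higher toxicity in this test and higher numbers for lower toxicity in this test. Its closest neighbor is compound 3 `ClCc1ccc(Cn2cnc3nc(Cl)nc(Cl)c32)cc1`, which gives 6600 nM in this assay, a gap within the scatter. Compound 2 `Nc1nc(Cl)c2ncn(Cc3ccc(CCl)cc3)c2n1` stands far away with 60300 nM; compound 1 holds the lowest number of the three, and only its distance to compound 2 lies beyond the scatter.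

Compound 4 `Nc1nc(Cl)c2ncn(Cc3ccccc3CCl)c2n1` has not yet been measured. It departs from compound 1 by one change: amino in place of chloro on an aromatic carbon. The same amino-for-chloro exchange separates compound 3 from compound 2, and those two measured values differ widely, with compound 2 giving the much higher number. In the absence of a directly measured step for this pair, a move of similar size toward a higher number is expected, an 8.6-fold higher number from compound 1 to compound 4 (0.93 log units; beyond the scatter), because compound 2 gives 60300 nM where compound 3 gives 6600 nM. Compound 4 is therefore estimated at 40000 nM, within a range from 15000 nM to 110000 nM.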

Compound 4, concentration lethal to 50% of the cells: 19500 nM
Compound 4: middle estimate off by 2.1-fold (0.31 log units), on the high side; measured number inside the range.
By their numbers in this assay, from the lowest: compounds 1 and 3 (each within the scatter of the next); then compound 4; then compound 2.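

The exchange of chloro for amino on the aromatic carbon between two ring nitrogen atoms now has a direct reading on the core of compound 1: in this assay, the step is a 4.2-fold higher number from compound 1 to compound 4 (0.62 log units; beyond the scatter), which means lower toxicity in this test. This position is therefore sensitive to the change, though the amino group does not abolish the read-out, as compound 4 still gives a measured 19500 nM. No measurement offered here accounts for this shift.

The compounds shown leave open how a methylamino, methoxy or hydroxyl group would read on this same carbon, and whether the step would scale with the size of such a group. From the compounds shown here alone, it also remains open whether an amino group on the other chlorinated ring carbon would give a step of similar size.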